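A few compounds are considered here, and "the series" means these few. Any claim that something is new, unique, unknown or untested is made for them only; others in the source may bear on it.

Measured compounds:
compound 1 `CC(C)c1ccc(-c2nc(SCc3cn(CC(=O)NC(=O)Nc4ccccn4)nn3)nc(Nc3ccccc3Cl)c2C#N)cc1`: 23400 nM
compound 2 `CC(C)c1ccc(-c2nc(SCc3cn(CC(=O)NC(=O)Nc4ccccn4)nn3)nc(Nc3ccc(Cl)cc3)c2C#N)cc1`: 11200 nM
compound 3 `CC(C)c1ccc(-c2nc(SCc3cn(CC(=O)NC(=O)Nc4ccccn4)nn3)nc(Nc3cccc([N+](=O)[O-])c3)c2C#N)cc1`: 31300 nM

All three were read in a functional assay on ECa-109 cells (Homo sapiens) for inhibition, read by MTT assay, with a stated time of 72 h; a lower number here means a stronger inhibitor, a higher number a weaker inhibitor. Compound 2 gives the lowest number of the three in this assay; the step of a 2.1-fold lower number from compound 1 to compound 2 (0.32 log units; beyond the scatter) and the step of a 2.8-fold higher number from compound 2 to compound 3 (0.45 log units; beyond the scatter) are both beyond the scatter, while a 1.3-fold higher number from compound 1 to compound 3 (0.13 log units; within the scatter) lies within it. Compound 4 `COc1cc(-c2nc(SCc3cn(CC(=O)NC(=O)Nc4ccccn4)nn3)nc(Nc3ccc(Cl)cc3)c2C#N)cc(OC)c1OC` differs from compound 2 elsewhere: 3,4,5-trimethoxyphenyl in place of 4-isopropylphenyl on an aromatic carbon. Among the compounds with values here, none of the measured steps touches this place; all three vary the group on a nitrogen on an aromatic ring and keep the 4-isopropylphenyl. Within the data shown here, no measured step therefore bears on this change, and no direction is indicated. The expected step is a 1.0-fold lower number from compound 2 to compound 4 (0.01 log units; within the scatter), with a wide range around it. Compound 4 is expected to give 11000 nM in this assay, between 3000 nM and 40000 nM.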

Compound 4, half-maximal inhibitory concentration: > 64000 nM
Compound 4: only a limit was reported; the forecaster's own chance of this, stated with the estimate: 10%; middle value at least 5.8-fold (0.76 log units) from the limit.
By their numbers in this assay, from the lowest: compound 2; then compounds 1 and 3 (each within the scatter of the next). At a limit, above all of these: compound 4.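

The aryl group on the aromatic carbon opposite the ring nitrogen matters in this assay: 3,4,5-trimethoxyphenyl in place of 4-isopropylphenyl gives an at least 5.7-fold higher number from compound 2 to compound 4 (0.75 log units; beyond the scatter), a larger step than any among the groups on the nitrogen. From the compounds shown here alone, compound 4 is reported only as a limit, > 64000 nM, so the true size of this step stays unknown.

The compounds shown do not separate the effect of adding methoxy groups from that of removing the isopropyl group. An unsubstituted phenyl, a single methoxyphenyl or a dimethylaminophenyl at this position would help to separate them.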